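The source may hold more compounds than are shown below. What is called first, only, known or untested is meant among the compounds shown, and "the series" means these compounds.

The measured compounds and their values in a functional assay with Alpha-1A adrenergic receptor (Homo sapiens) as the target, read by calcium flux; on this read-out lower numbers stand for smaller maximal responses and higher numbers for larger maximal responses:

compound 1 `c1coc(-c2ccccc2OCC2=NCCN2)c1`: 106%
compound 2 `c1c[nH]c(-c2ccccc2OCC2=NCCN2)c1`: 99%
compound 3 `c1ccc(-c2ccoc2)c(OCC2=NCCN2)c1`: 104%

Compound 3 stands second highest of the three numbers in this assay. The step nearest to it is a number 2 percentage points lower from compound 1 to compound 3 (within the scatter), and the furthest is a number 5 percentage points higher from compound 2 to compound 3 (within the scatter). The remaining step among the measured compounds is a number 7 percentage points lower from compound 1 to compound 2 (within the scatter), so all three ring swaps on the shared core left the maximal response where it was.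

Compound 4 `c1ccc(-c2ccns2)c(OCC2=NCCN2)c1` differs from compound 3 by a single change: 1,2-thiazol-5-yl in place of furan-3-yl on an aromatic carbon. Among the compounds with values here, no measured step brings in a 1,2-thiazol-5-yl, so the new ring itself has no direct precedent here. Within the data shown here, the steps that bear on it are the three five-membered ring exchanges above, each within the scatter, which suggests that swapping one such ring for another on this core changes little in this assay. On that basis the expected step is a number 3 percentage points lower from compound 3 to compound 4 (within the scatter), with no change beyond the scatter. Compound 4 is therefore estimated at 101% in this assay, within a range of 84% to 115%.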

Compound 4, largest response reached (reported as maximum), in percent of the reference or control that the assay uses: 99%
Compound 4: the middle estimate sits 2 percentage points above what was measured; the range from low to high includes it.
By their numbers in this assay, from the lowest: compounds 2, 4, 3 and 1 (each within the scatter of the next).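

Within the data shown here, compound 4 brings a sulfur and a second ring hetero atom to this position on the six-membered aromatic ring, where the earlier compounds carried only furan-2-yl, furan-3-yl or 1H-pyrrol-2-yl. In this assay, 1,2-thiazol-5-yl gives a number 5 percentage points lower from compound 3 to compound 4 (within the scatter), no change at the digits printed from compound 2 to compound 4 (within the scatter) and a number 7 percentage points lower from compound 1 to compound 4 (within the scatter), so all three exchanges leave the maximal response unchanged and the tolerance seen among the earlier rings extends to this one. No evidence on the cause accompanies this result.

The compounds shown leave open whether a group of another kind at this place, such as an amine, a carboxylic acid or a longer alkyl chain, would move the maximal response in this assay beyond the scatter. They also leave open whether 1,2-thiazol-4-yl would behave like 1,2-thiazol-5-yl.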